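Removing One Methoxy Group: Expected Cytotoxicity at One Dose

The source may hold more compounds than are shown below. What is called first, only, known or untested is meant among the compounds shown, and "the series" means these compounds.

Measured so far:
Compound 1, `COc1ccc(-c2cc(/C=C/C(=O)c3ccc(N)cc3)[nH]n2)cc1`: 85%
Compound 2, `COc1cc(-c2cc(/C=C/C(=O)c3ccc(N)cc3)[nH]n2)cc(OC)c1OC`: 98%

Both compounds were tested in a functional assay on NCI/ADR-RES cells (Homo sapiens) for cytotoxicity, read by sulforhodamine B assay, with a stated time of 48 h, tested at 1 uM; a higher number here means a weaker effect of the compound at the concentration tested, a lower number a stronger effect. Compound 2 gives the higher of the two numbers, 98%, and therefore the weaker effect at this concentration; compound 1 sits lower at 85%, a gap that lies beyond the usual scatter. Compound 3, `COc1ccc(-c2cc(/C=C/C(=O)c3ccc(N)cc3)[nH]n2)cc1OC`, has not yet been measured. It differs from compound 2 in one place: hydrogen in place of methoxy on an aromatic carbon. For the measured compounds named here, no step between measured compounds isolates this change, so the expected size of the step from compound 2 to compound 3 in this assay is uncertain; a small move downward, toward the number of compound 1, or no step beyond the scatter, seems most plausible, and the estimated step is a number 7 percentage points lower from compound 2 to compound 3 (within the scatter). Compound 3 is expected to give about 91% in this assay, within a range of 76% to 102%.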

Compound 3, a percentage reported as activity, at one concentration (the size of the read-out at that concentration, not a potency): 99%
Beside the measured number, compound 3's estimate is 8 percentage points below it; the range from low to high includes it.
By their numbers in this assay, from the lowest: compound 1; then compounds 2 and 3 (each within the scatter of the next).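

In this assay, replacing the methoxy on the aromatic carbon ortho to a methoxy group with hydrogen gives a number 1 percentage points higher from compound 2 to compound 3 (within the scatter), so losing this group leaves the number unchanged within the scatter. Adding a methoxy to compound 1 tells a different story, with a number 14 percentage points higher from compound 1 to compound 3 (beyond the scatter), which means a weaker effect at this dose for compound 3. The two steps thus show that swapping hydrogen and methoxy on this ring can matter in one compound and not in another, but nothing available here explains the difference.

From the compounds shown here alone, whether a hydroxy group or a fluorine atom on this aromatic carbon would behave like hydrogen or like methoxy remains open. These numbers come from a single concentration, so they show only how strong or weak the effect of all three compounds is at that concentration.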